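Anilino substituent swap: compound 3 to compound 4

The source may hold more compounds than are shown below. What is called first, only, known or untested is meant among the compounds shown, and "the series" means these compounds.

Measured so far in a functional assay on MDA-MB-231 cells (Homo sapiens) for inhibition, read by MTT assay, with a stated time of 72 h; a higher number here means a weaker inhibitor, a lower number a stronger inhibitor:
compound 1 `C=CC(=O)Nc1cccc(NC(=O)CSc2nc(Nc3cccc(F)c3)c3ccccc3n2)c1`: 8160 nM
compound 2 `C=CC(=O)Nc1cccc(NC(=O)CSc2nc(Nc3cccc(C)c3)c3ccccc3n2)c1`: 16800 nM
compound 3 `C=CC(=O)Nc1cccc(NC(=O)CSc2nc(Nc3cccc(OC)c3)c3ccccc3n2)c1`: 12900 nM

All three share one core and differ only in the group on the anilino ring. On the numbers, compound 3 lies between compound 1 and compound 2, and its steps to both fall within the scatter, so the three are not separated in this assay beyond the modest step of a 2.1-fold higher number from compound 1 to compound 2 (0.31 log units; beyond the scatter).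

Compound 4 `C=CC(=O)Nc1cccc(NC(=O)CSc2nc(Nc3ccc(CC)cc3)c3ccccc3n2)c1` differs from compound 3 by 4-ethylphenyl in place of 3-methoxyphenyl on a nitrogen on an aromatic ring. For the measured compounds named here, the steps that bear on this are the three substituent exchanges on the same ring: a 2.1-fold higher number from compound 1 to compound 2 (0.31 log units; beyond the scatter), a 1.6-fold higher number from compound 1 to compound 3 (0.20 log units; within the scatter) and a 1.3-fold lower number from compound 2 to compound 3 (0.11 log units; within the scatter). Even the largest of them is modest; the others stay within the scatter. Going by the values given here, no measured step covers an ethyl group or the 4-position of that ring, so the new change is only loosely anchored. The expected step is therefore small, a 1.2-fold higher number from compound 3 to compound 4 (0.07 log units; within the scatter), likely not beyond the scatter and with no firm direction. Compound 4 is expected to give about 15000 nM, in the range 6000 nM to 40000 nM.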

Compound 4, half-maximal inhibitory concentration: 14400 nM
The estimate for compound 4 lay 1.0-fold (0.02 log units) above the measured number; low and high end bracket the measured number.
By their numbers in this assay, from the lowest: compounds 1, 3, 4 and 2 (each within the scatter of the next, the first and the last beyond it).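

In this assay, the exchange of 3-methoxyphenyl for 4-ethylphenyl on the nitrogen gives a 1.1-fold higher number from compound 3 to compound 4 (0.05 log units; within the scatter), and the comparison with 3-methylphenyl gives a 1.2-fold lower number from compound 2 to compound 4 (0.07 log units; within the scatter), so a change of both the group and its place on the ring does not separate these compounds. Against 3-fluorophenyl the step is a 1.8-fold higher number from compound 1 to compound 4 (0.25 log units; within the scatter), which leaves a 2.1-fold higher number from compound 1 to compound 2 (0.31 log units; beyond the scatter) as the only step in the series beyond the scatter, and a modest one. No measured data on the series offer an explanation for this flat result.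

A 3-ethylphenyl or 4-methoxyphenyl compound would separate the effect of the group from that of its place on the ring. As far as these compounds go, whether an amine, a carboxylic acid or a longer chain on this ring would give a larger step remains open.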